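This account rests on a few compounds, and the source may have more. Where it says the series, first, only, none or still open, it means among the compounds named here.

Measured compounds in a functional assay on the whole organism with Mus musculus as the target; on this read-out lower numbers stand for an effect already at smaller amounts and higher numbers for an effect only at larger amounts of compound:
compound 1 `CCCCSc1nsnc1[C@H]1CN2CCC[C@H]1C2` — compound 1 gives > 1 mg/kg, a limit of the assay.
compound 2 `CCCCSc1nsnc1[C@@H]1CN2CCC[C@H]1C2` — compound 2 gives > 3 mg/kg, a limit of the assay.
compound 3 `CCCCSc1nsnc1[C@H]1CN2CCC[C@@H]1C2` — compound 3 gives > 0.3 mg/kg, a limit of the assay.

Going by the values given here, compound 3 stands at one of three limits in this assay; the three values sit at the limit of > 0.3 mg/kg in this assay, at which 1 of the 3 values shown sits, the limit of > 1 mg/kg in this assay, at which 1 of the 3 values shown sits, and (the limit of > 3 mg/kg in this assay, at which 1 of the 3 values shown sits), so no compound of the series has a number yet. The steps among the measured compounds, a step that the two limits leave unreadable from compound 1 to compound 2, a step that the two limits leave unreadable from compound 1 to compound 3 and a step that the two limits leave unreadable from compound 2 to compound 3, are all left unreadable by the limits, and each of them is a change of configuration at a saturated ring carbon only; none alters the chain on the sulfur.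

Compound 4 `CCCSc1nsnc1[C@H]1CN2CCC[C@@H]1C2` differs from compound 3 by hydrogen in place of methyl on a saturated chain carbon, three bonds along the chain from a sulfur. Among the compounds with values here, no measured step touches this change, so nothing indicates a step in either direction beyond the scatter. For compound 4 the expected step from compound 3 is therefore a step that the limit leaves unreadable from compound 3 to compound 4. Compound 4 is estimated at 1 mg/kg in this assay, with a range from 0.3 mg/kg to 3 mg/kg, and a limit rather than a number is the likelier outcome.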

Compound 4, dose for half-maximal effect: > 3 mg/kg
Compound 4: only a limit was reported; the forecaster's own chance of this, stated with the estimate: 70%; middle value at least 3.0-fold (0.47 log units) from the limit.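

In this assay, compound 3 and compound 4 both stand at limits of the assay, so no step can be read between them. The compounds shown leave open whether going from butyl to propyl changes the read-out at all, and in which direction, as no compound yet has a number.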